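A few compounds are considered here, and "the series" means these few. Any claim that something is new, unique, unknown or untested is made for them only; others in the source may bear on it.

Measured so far: compound 1 `Cc1cccc(Cc2nc3cc(O[C@H]4CC[C@@H](C(=O)O)CC4)ccc3n2C)c1` gives 30 nM; compound 2 `Cc1cccc(Cc2nc3cc(O[C@H]4CC[C@@H](C(=O)O)CC4)c(Cl)cc3n2C)c1` gives 100 nM.

Compound 1 stands lowest of the two numbers in an assay on isolated protein for inhibition of Long-chain-fatty-acid--CoA ligase 1 (Mus musculus), read by mass spectrometry, with a stated time of 90 min, in the presence of a further agent that is not named here; on this read-out lower numbers stand for stronger inhibition and higher numbers for weaker inhibition. Its nearest neighbour is compound 2, reached by a 3.3-fold higher number from compound 1 to compound 2 (0.52 log units; beyond the scatter), a chloro in place of hydrogen on an aromatic carbon of the shared core; that step is modest but beyond the scatter.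

Compound 3 `Cc1cccc(Cc2nc3cc(O[C@H]4CC[C@@H](C(N)=O)CC4)ccc3n2C)c1` is not yet measured. It differs from compound 1 by amino in place of hydroxy on a carbonyl carbon, which, cut one bond further out, reads carboxy to carbamoyl, or 4-carboxycyclohexyl to 4-carbamoylcyclohexyl. For the measured compounds named here, no measured step touches the carbonyl carbon or the carboxy group; the single step from compound 1 to compound 2 sits on the aromatic part of the core and does not bear on this change. The data therefore give no direct anchor for the size or direction of the step, and the expectation below rests on the starting point of compound 1 alone.

The step from compound 1 to compound 3 in this assay is expected to be a 10-fold higher number from compound 1 to compound 3 (1.00 log units; beyond the scatter), leaning toward a higher number, with wide uncertainty. Compound 3 is estimated at 300 nM, in the range 60 nM to 3000 nM.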

Compound 3, half-maximal inhibitory concentration: 190 nM
Estimate against measurement, compound 3: 1.6-fold (0.20 log units) above, within the range that was stated.
By their numbers in this assay, from the lowest: compound 1; then compounds 2 and 3 (each within the scatter of the next).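

In this assay, for the compounds shown here, amino in place of hydroxy on a carbonyl carbon gives a 6.3-fold higher number from compound 1 to compound 3 (0.80 log units; beyond the scatter), the first reading of a change at this carbonyl carbon, since the earlier step touched only the aromatic part of the shared core. The carboxy group therefore favours the lower number in this pair, but inhibition does not depend on it outright: with carbamoyl in its place, compound 3 still reads 190 nM. Nothing on hand accounts for the size of this step, so the observation stands without an explanation.

Going by these compounds, it remains open how other groups would read on the same carbonyl carbon, for example a methyl ester or an N-methyl amide, or how a tetrazole would read in place of the whole carboxy group. On these data alone, it is also open whether carboxy to carbamoyl gives a step of similar size on the chloro-bearing core of compound 2, which would show whether this change and the chloro step add up independently.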